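A few compounds are considered here, and "the series" means these few. Any claim that something is new, unique, unknown or untested is made for them only; others in the source may bear on it.

In a functional assay on RAW264.7 cells (Mus musculus) for inhibition, read by Griess assay, with stated times of 1 h and 24 h (on this read-out higher numbers stand for weaker inhibition and lower numbers for stronger inhibition), compound 1 `CCCCOc1ccc(C(O)C2OC(=O)c3c(OC)cc(OC)cc32)cc1` gives 1800 nM. Compound 2 `CCC(C)Oc1ccc(C(O)C2OC(=O)c3c(OC)cc(OC)cc32)cc1` stands only at a limit of the assay, > 10000 nM. Compound 3 `COc1cc(OC)c2c(c1)C(C(O)c1ccc(OCCOc3ccccc3)cc1)OC2=O` differs from compound 2 by 2-phenoxyethyl in place of sec-butyl on an oxygen on an aromatic ring, with 2-phenoxyethyl in place of sec-butyl on an oxygen on an aromatic ring. Within the data shown here, the one measured step at this oxygen is an at least 5.5-fold higher number from compound 1 to compound 2 (0.74 log units; beyond the scatter). Compound 3 no longer carries the sec-butyl of that step, so its number is expected to fall towards that of compound 1, 1800 nM. The expected change in this assay, towards stronger inhibition, is an at least 3.3-fold lower number from compound 2 to compound 3 (0.52 log units; beyond the scatter). Compound 3 is estimated at 3000 nM, within an expected range of 800 nM to 10000 nM.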

Compound 3, half-maximal inhibitory concentration: > 10000 nM
Compound 3: only a limit was reported (the forecaster's own chance of this, stated with the estimate: 20%); middle value at least 3.3-fold (0.52 log units) from the limit.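

In this assay, a second replacement at this oxygen also loses inhibition, with an at least 5.5-fold higher number from compound 1 to compound 3 (0.74 log units; beyond the scatter). Of the groups shown on this oxygen, then, sec-butyl is not alone in falling short of butyl, since 2-phenoxyethyl, which brings a six-membered aromatic ring, does so too. The step from compound 2 to compound 3 cannot be read: the limit of > 10000 nM in this assay, at which 2 of the 3 values shown sit.

The compounds shown leave open whether a propyl or pentyl chain on this oxygen would match compound 1 at 1800 nM. Also open, on these data alone, is whether an amine or a carboxylic acid at the end of the butyl chain would be tolerated.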